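The compounds below may be only part of what the source reports. "The series", "measured", "known", "first", "only" and "open" are said of these compounds alone.

For the measured compounds named here, compound 1 `CCCCC[Se]c1nc([Se]CCCCC)c2ccccc2n1` and compound 2 `Sc1nc(NCc2ccccc2)c2ccccc2n1` share the same core and are the only two compounds with a result so far. In a functional assay on CCRF-CEM cells (Homo sapiens) for cytotoxicity, read by MTT assay, with a stated time of 72 h (a higher number here means that more compound is tolerated, a lower number that less compound is tolerated), compound 1 gives > 100000 nM, which is a limit of the assay rather than a number. In this assay compound 2 likewise gives > 100000 nM, again a limit of the assay and not a measured value. Compound 2 therefore stands at the limit of > 100000 nM in this assay, at which 2 of the 2 values shown sit, and the two values show nothing that would order one compound against the other. Compound 3 `CCCCC[Se]c1nc(NCc2ccccc2)c2ccccc2n1` has not yet been measured. It differs from compound 2 by a group of 6 heavy atoms (5 carbon, 1 selenium; no ring) in place of one sulfur atom, on an aromatic carbon. Going by the values given here, no step between two measured compounds is available to calibrate such a change, so the expectation for compound 3 rests only on where compound 2 sits. The expected change is a number no higher from compound 2 to compound 3 (the limit leaves the size open), which is no more than the ordinary scatter. Compound 3 is thus estimated at 100000 nM, with a range from 30000 nM to 300000 nM, and the assay may well again report only a limit for it.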

Compound 3, concentration lethal to 50% of the cells: > 100000 nM
Compound 3 was reported as a limit (the forecaster's own chance of this, stated with the estimate: 70%); the middle value sits exactly at the limit.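

No step can be read among compound 1, compound 2 and compound 3, since in this assay each result is only a limit of the assay and not a number: the limit of > 100000 nM in this assay, at which 3 of the 3 values shown sit. The compounds shown leave open how the three compare with one another and whether any change on the shared core alters the result in this assay.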